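The source may report more compounds than this note shows. Statements on the series, on what has been measured and on what is new or still open speak of the compounds shown alone.

Measured so far in a functional assay on L1210 cells (Mus musculus); a lower number here means a stronger inhibitor, a higher number a weaker inhibitor:
compound 1 `CCCNC(=O)Nc1ccc(C(C)C)cc1`: 14000 nM
compound 2 `CCCNC(=O)Nc1ccc(C(C)(C)C)cc1`: 5400 nM
compound 3 `CCNC(=O)Nc1ccc(C(C)CC)cc1`: 43000 nM

Compound 2 gives the lowest of the three numbers and compound 3 the highest. Within the data shown here, the one counted step between measured compounds is hydrogen in place of methyl on a saturated chain carbon bound to an aromatic carbon and two saturated chain carbons, which made a 2.6-fold higher number from compound 2 to compound 1 (0.41 log units; beyond the scatter). How the core of compound 3 differs from the core of compound 2 is not broken down here.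

Compound 4 `CCC(C)c1ccc(NC(=O)NC)cc1` is not yet measured. It differs from compound 3 by hydrogen in place of methyl on a saturated chain carbon bound to an amide-type nitrogen. Among the measured compounds shown here, this is the same kind of change as the one between compound 2 and compound 1, but not the same: there the carbon is bound to an aromatic carbon and two saturated chain carbons, here to an amide-type nitrogen. A step of a 1.9-fold higher number from compound 3 to compound 4 (0.27 log units; within the scatter) is expected, resting on a 2.6-fold higher number from compound 2 to compound 1 (0.41 log units; beyond the scatter) and on compound 3 already standing at 43000 nM. Compound 4 is estimated at 80000 nM, between 30000 nM and 200000 nM.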

Compound 4, half-maximal inhibitory concentration: 62000 nM
Compound 4: the middle estimate sits 1.3-fold (0.11 log units) above what was measured; the range from low to high includes it.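

In this assay, hydrogen in place of methyl on a saturated chain carbon bound to an amide-type nitrogen gives a 1.4-fold higher number from compound 3 to compound 4 (0.16 log units; within the scatter) on the core of compound 3. Set beside the step on the core of compound 2, the two do not differ beyond what repeated measurement allows: the same change on two cores in this assay, a 2.6-fold higher number (0.41 log units; beyond the scatter) from compound 2 to compound 1 and a 1.4-fold higher number (0.16 log units; within the scatter) from compound 3 to compound 4, 1.8-fold (0.25 log units) apart, within the scatter of two such steps. Among these compounds, this supports carrying the change between these two cores, but each core supplies only one pair, the carbon that changes is not the same in the two pairs, and the newer step alone cannot be told from no change.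

Still open, going by these compounds, is whether a longer chain on the amide-type nitrogen, such as butyl, would give a step beyond the scatter. An amine or a carboxylic acid at that chain's end is equally untested among the compounds shown.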